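Swapping the Aryl Amide: From Compound 3 to Compound 4

A few compounds are considered here, and "the series" means these few. Any claim that something is new, unique, unknown or untested is made for them only; others in the source may bear on it.

In a functional assay on the whole organism (blood) with Rattus norvegicus as the target, with stated times of 24 h and 1 h, at a dose of 15 mg/kg by the intraperitoneal route (on this read-out lower numbers stand for a weaker effect and higher numbers for a stronger effect at the one dose given), compound 1 `COc1ccc(C(=O)NCCC2CCN(S(=O)(=O)NC(=O)NC[C@@H]3C[C@@H]4C=C[C@@H]3C4)CC2)cn1` gives 32%, compound 2 `O=C(NC[C@@H]1C[C@@H]2C=C[C@@H]1C2)NS(=O)(=O)N1CCC(CCNC(=O)c2cc(Cl)ccn2)CC1` gives 46%, and compound 3 `O=C(NC[C@@H]1C[C@@H]2C=C[C@@H]1C2)NS(=O)(=O)N1CCC(CCNC(=O)c2cnccc2Cl)CC1` gives 12%, the lowest of the three numbers. The gaps read a number 20 percentage points lower from compound 1 to compound 3 (beyond the scatter) and a number 34 percentage points lower from compound 2 to compound 3 (beyond the scatter), while a number 14 percentage points higher from compound 1 to compound 2 (beyond the scatter). Compound 4 `O=C(NC[C@@H]1C[C@@H]2C=C[C@@H]1C2)NS(=O)(=O)N1CCC(CCNC(=O)c2cccc3c2OCCO3)CC1` differs from compound 3 only at the carbonyl carbon: 2,3-dihydro-1,4-benzodioxin-5-yl in place of 4-chloropyridin-3-yl on a carbonyl carbon. Every measured step likewise exchanged the group on that carbonyl carbon and moved the read-out beyond the scatter, with 4-chloropyridin-3-yl giving the weakest result. Leaving that group behind in compound 4 is therefore expected to raise the read-out, a number 23 percentage points higher from compound 3 to compound 4 (beyond the scatter). Compound 4 is estimated at 35%, with a range from 15% to 60%.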

Compound 4, a percentage reported as activity, at one dose (the size of the read-out at that dose, not a potency): 40%
Beside the measured number, compound 4's estimate is 5 percentage points below it; measured number inside the range.
By their numbers in this assay, from the lowest: compound 3; then compounds 1, 4 and 2 (each within the scatter of the next, the first and the last beyond it).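

In this assay the carbonyl carbon proves to need no pyridine: 2,3-dihydro-1,4-benzodioxin-5-yl, whose aromatic ring is of carbon only, gives a number 28 percentage points higher from compound 3 to compound 4 (beyond the scatter). It also gives a number 6 percentage points lower from compound 2 to compound 4 (within the scatter) and a number 8 percentage points higher from compound 1 to compound 4 (within the scatter), so among these groups it stands level with both the 4-chloropyridin-2-yl and 6-methoxypyridin-3-yl groups. Nothing available explains these steps. From the compounds shown here alone, whether the non-aromatic ring with its two oxygens contributes remains open, and a plain phenyl on the same carbonyl carbon would separate its part from that of the aromatic ring.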